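Adding a propyl group to the ring nitrogen of compound 2

A few compounds are considered here, and "the series" means these few. Any claim that something is new, unique, unknown or untested is made for them only; others in the source may bear on it.

Among the compounds with values here, compound 2 `C(=C/c1ccccc1OCCCCN1CCNCC1)\c1ccccc1` stands lowest of the two compounds measured so far: in a functional assay on the whole organism with Mus musculus as the target, at a dose of 50 mg/kg by the oral route (a lower number here means less inhibition, a higher number more inhibition at the dose given (going by the name of the read-out)), compound 2 gives 0%, while compound 1 `OC1CCN(CCCCOc2ccccc2/C=C/c2ccccc2)CC1` gives 50%. Within the data shown here, the only measured step, a number 50 percentage points lower from compound 1 to compound 2 (beyond the scatter), swaps the whole ring, not a single substituent. Compound 3 `CCCN1CCN(CCCCOc2ccccc2/C=C/c2ccccc2)CC1` differs from compound 2 by propyl in place of hydrogen on an amine nitrogen in a ring. Among the measured compounds shown here, no measured step mirrors this change, so the direction is uncertain; a modest rise toward the level of compound 1 is expected, as a number 20 percentage points higher from compound 2 to compound 3 (beyond the scatter). Compound 3 is therefore estimated at 20%, within 0% to 55%.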

Compound 3, a percentage reported as inhibition, in the whole organism at one dose (the size of the read-out at that dose, not a potency): 87.5%
Estimate against measurement, compound 3: 67.5 percentage points below; measured number above the stated range.
By their numbers in this assay, from the lowest: compound 2; then compound 1; then compound 3.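

In this assay, propyl in place of hydrogen on the amine nitrogen in the ring gives a number 87.5 percentage points higher from compound 2 to compound 3 (beyond the scatter), so this nitrogen is a position where the read-out responds strongly to what is attached. The low figure for compound 2 therefore does not hold for every compound with this ring: 4-propylpiperazin-1-yl in place of 4-hydroxypiperidin-1-yl gives a number 37.5 percentage points higher from compound 1 to compound 3 (beyond the scatter), leaving the propyl compound above the hydroxypiperidine. No measurement at hand accounts for this rise. The compounds shown carry only hydrogen or propyl on this nitrogen. As far as these compounds go, how a methyl group, a longer butyl chain or a benzyl group would read remains open.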